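Thiophen-3-yl for thiophen-2-yl: two measured, one to estimate

This account rests on a few compounds, and the source may have more. Where it says the series, first, only, none or still open, it means among the compounds named here.

Measured so far:
- compound 1 `CC(=O)Oc1cccc2cc(-c3ccsc3)c(=O)oc12`: > 30000 nM
- compound 2 `O=c1oc2c(O)cccc2cc1-c1cccs1`: > 30000 nM

In a functional assay on isolated protein for antagonist activity at adenosine receptor A2b (Homo sapiens) (on this read-out lower numbers stand for stronger inhibition and higher numbers for weaker inhibition), compound 1 reaches only the assay limit, > 30000 nM. In this assay compound 2 likewise reaches only the limit, > 30000 nM. Within the data shown here, compound 2 therefore stands at the limit shared by both values shown, (the limit of > 30000 nM in this assay, at which 2 of the 2 values shown sit), and no step between measured compounds is available.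

Compound 3 `O=c1oc2c(O)cccc2cc1-c1ccsc1` differs from compound 2 by thiophen-3-yl in place of thiophen-2-yl on an aromatic carbon. Without a measured step, the expectation is no change beyond the scatter, so compound 3 is expected at 30000 nM, in the range 10000 nM to 100000 nM, most likely again a limit, with the step from compound 2 to compound 3 estimated as a number no higher from compound 2 to compound 3 (the limit leaves the size open).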

Compound 3, inhibition constant: > 30000 nM
Compound 3: only a limit was reported; the forecaster's own chance of this, stated with the estimate: 80%; the middle value sits exactly at the limit.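

The steps from compound 2 to compound 3 and from compound 1 to compound 3 cannot be read, because all three compounds sit at a limit: the limit of > 30000 nM in this assay, at which 3 of the 3 values shown sit.
The compounds shown leave open whether thiophen-3-yl in place of thiophen-2-yl, or hydrogen in place of acetyl, changes inhibition at all.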